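From methyl to methoxycarbonyl on compound 2

The source may hold more compounds than are shown below. What is called first, only, known or untested is meant among the compounds shown, and "the series" means these compounds.

Compound 1 `C=c1[nH]c(=O)/c(=C/c2ccc(C(C)(C)C)cc2)[nH]c1=O`: > 20000 nM, a limit
Compound 2 `C=c1[nH]c(=O)/c(=C/c2ccc(C)cc2)[nH]c1=O`: > 20000 nM, a limit
Compound 3 `C=c1[nH]c(=O)/c(=C/c2cc(OC)c(OC)c(OC)c2)[nH]c1=O`: > 20000 nM, a limit

In a functional assay on Huh7.5.1 cells (Homo sapiens) for cytotoxicity, read by MTT assay, with a stated time of 72 h (a higher number here means that more compound is tolerated, a lower number that less compound is tolerated), compound 2 gives > 20000 nM, which is a limit and not a number. Compound 4 `C=c1[nH]c(=O)/c(=C/c2ccc(C(=O)OC)cc2)[nH]c1=O` differs from it by one change, (methoxycarbonyl in place of methyl on an aromatic carbon), with methoxycarbonyl in place of methyl on an aromatic carbon. Among the compounds with values here, the only measured step that bears on this is a step that the two limits leave unreadable from compound 1 to compound 2, so it offers no size to carry over. What the series does show is the limit of > 20000 nM in this assay, at which 3 of the 3 values shown sit. On that basis, no change beyond the scatter is expected in this assay, and no direction is favoured. The expected step is a step that the limit leaves unreadable from compound 2 to compound 4. For compound 4 the estimated value is 25000 nM, with an expected range from 12000 nM to 50000 nM, and the assay will most likely report only a limit.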

Compound 4, half-maximal cytotoxic concentration: > 20000 nM
Compound 4: only a limit was reported; the forecaster's own chance of this, stated with the estimate: 85%; the middle value does not contradict the limit.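

Within the data shown here, compound 4 gives > 20000 nM in this assay, which is a limit, so no step from compound 2 or compound 1 to compound 4 can be read. The compounds shown leave open at what concentration any of them becomes cytotoxic, and whether their groups differ in this respect.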